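The compounds below may be only part of what the source reports. "The series", "measured", "known", "first", "only" and "open" are said of these compounds alone.

Three compounds here share one core, a sulfonamide-linked aryl oxazole bearing a cyclopropyl group, and differ only in the single substituent on the fused aromatic ring. Compound 1 `Nc1ccc2c(c1)OCCCN2S(=O)(=O)c1ccc(-c2cnc(C3CC3)o2)cc1` carries an amino group there; in a functional assay on HepG2 cells (Homo sapiens) for antiproliferative activity, read by MTT assay, with a stated time of 72 h (a lower number here means a stronger inhibitor, a higher number a weaker inhibitor), compound 1 gives 100 nM. Compound 2 `O=S(=O)(c1ccc(-c2cnc(C3CC3)o2)cc1)N1CCCOc2ccc(F)cc21` carries a fluoro and gives 36 nM in this assay, while compound 3 `COc1ccc2c(c1)N(S(=O)(=O)c1ccc(-c3cnc(C4CC4)o3)cc1)CCCO2` carries a methoxy and gives 49 nM. Of the three numbers, compound 1 stands highest, so it is the weakest inhibitor of the set, with compound 3 nearest to it and compound 2 furthest away.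

Compound 4 `COc1ccc2c(c1)OCCCN2S(=O)(=O)c1ccc(-c2cnc(C3CC3)o2)cc1` is the yet unmeasured member: methoxy in place of amino on an aromatic carbon.

Among the measured compounds shown here, only one measured step bears on this change. Going from fluoro to methoxy gave a 1.4-fold higher number from compound 2 to compound 3 (0.13 log units; within the scatter), so swapping one small substituent for another left the number essentially where it was. For the measured compounds named here, the amino-to-methoxy swap has no direct precedent, but both compound 2 and compound 3 show that substituents other than amino in this position give lower numbers than compound 1. A modest step downward in this assay is therefore expected, of about a 2.0-fold lower number from compound 1 to compound 4 (0.30 log units; within the scatter). Compound 4 is estimated to give 50 nM, with a likely range from 25 nM to 100 nM.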

Compound 4, half-maximal inhibitory concentration: 229 nM
The estimate for compound 4 lay 4.6-fold (0.66 log units) below the measured number, outside the stated range (above it).
By their numbers in this assay, from the lowest: compounds 2 and 3 (each within the scatter of the next); then compound 1; then compound 4.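

In this assay, among the compounds shown here, the swap gives a 2.3-fold higher number from compound 1 to compound 4 (0.36 log units; beyond the scatter), so on this aromatic carbon methoxy does not lower the number, and amino, which had the highest number among the earlier compounds, is the stronger of these two groups here. The step is modest but beyond the scatter. Amino stood highest among the earlier compounds, yet methoxy in its place did not lower the number. The swap loses the 1 hydrogen-bond donor of amino, keeps 1 hydrogen-bond acceptor, and goes from 1 heavy atom to 2, but no measurement shown here links the rise to any of these differences or offers another explanation for it.

Still open, as far as these compounds go, is which of those differences matters, since one pair cannot separate them. A hydroxy group at the same place would keep a hydrogen-bond donor, a dimethylamino group would keep the nitrogen without that donor, and an ethoxy group would extend the methoxy chain, so their values in this assay could help tell these differences apart.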